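From thiophen-2-yl sulfonyl to carbonyl

This account rests on a few compounds, and the source may have more. Where it says the series, first, only, none or still open, it means among the compounds named here.

In a functional assay on HCT-116 cells (Homo sapiens) for antiproliferative activity, read by WST assay, with a stated time of 72 h (on this read-out lower numbers stand for stronger inhibition of growth and higher numbers for weaker inhibition of growth), compound 2 (`O=C(NO)c1cnc(N2C[C@@H]3[C@H](C2)[C@H]3NS(=O)(=O)c2cccs2)nc1`) gives > 10000 nM as a limit and not a number, and it sits at the limit of > 10000 nM in this assay, at which 1 of the 3 values shown sits, here.

Compound 4 (`O=C(NO)c1cnc(N2C[C@@H]3[C@H](C2)[C@H]3NC(=O)c2cccs2)nc1`) carries (thiophen-2-yl)carbonyl in place of (thiophen-2-yl)sulfonyl on an amine nitrogen.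

With naphthalen-2-yl, the same exchange links compound 1 (`O=C(NO)c1cnc(N2C[C@@H]3[C@H](C2)[C@H]3NS(=O)(=O)c2ccc3ccccc3c2)nc1`) at 440 nM and compound 3 (`O=C(NO)c1cnc(N2C[C@@H]3[C@H](C2)[C@H]3NC(=O)c2ccc3ccccc3c2)nc1`) at 410 nM and these two values lie within the scatter of each other.

Going by the values given here, the one measured step, an at least 22-fold higher number from compound 1 to compound 2 (1.35 log units; beyond the scatter), is the exchange of naphthalen-2-yl for thiophen-2-yl, and compound 4 keeps thiophen-2-yl.

The expected change in this assay is a number no higher from compound 2 to compound 4 (the limit leaves the size open) and no step beyond the scatter is expected.

For compound 4 the estimate is 10000 nM with an expected range of 3000 nM to 30000 nM and a limit remains likely.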

Compound 4, concentration for 50% growth inhibition: 3600 nM
Estimate against measurement, compound 4: 2.8-fold (0.44 log units) above, and the stated range covers the measured number.
By their numbers in this assay, from the lowest: compounds 3 and 1 (each within the scatter of the next); then compound 4. At a limit, above all of these: compound 2.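

In this assay, (thiophen-2-yl)carbonyl in place of (thiophen-2-yl)sulfonyl on an amine nitrogen gives a step beyond the scatter, an at least 2.7-fold lower number from compound 2 to compound 4 (0.44 log units; beyond the scatter). With naphthalen-2-yl, the same exchange leaves compound 1 and compound 3 within the scatter of each other, so in these two pairs its outcome differs with the group it carries. Compound 2 gives a limit and not a number: the limit of > 10000 nM in this assay, at which 1 of the 4 values shown sits.

Going by these compounds, the full size of the step remains open. Also open, on these data alone, is how a phenyl group on the carbonyl or sulfonyl would behave.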